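The source may hold more compounds than are shown below. What is called first, only, known or untested is meant among the compounds shown, and "the series" means these compounds.

In a functional assay on BGC-823 cells (Homo sapiens) for cytotoxicity, read by CCK-8 assay, with a stated time of 24 h (on this read-out higher numbers stand for weaker inhibition and lower numbers for stronger inhibition), compound 1 `C/C(=C\c1cc(-c2ccc(F)cc2)co1)C(N)=O` gives only a limit, > 50000 nM. Compound 2 `C/C(=C\c1cc(-c2ccc(F)nc2)co1)C(N)=O` likewise gives only a limit in this assay, > 50000 nM. Compound 3 `C/C(=C\c1cc(-c2ccc(C)cc2)cs1)C(N)=O` also reaches only a limit in this assay, > 50000 nM. On the numbers shown compound 3 therefore stands at the bound itself (the limit of > 50000 nM in this assay, at which 3 of the 3 values shown sit), with no measured step to set it against compound 1 or compound 2. Compound 4 `C/C(=C\c1cc(-c2ccc(S(C)(=O)=O)cc2)cs1)C(N)=O` differs from compound 3 by methylsulfonyl in place of methyl on an aromatic carbon. Within the data shown here, no measured step covers this change, and with every value sitting at a limit no direction is given. The expected step from compound 3 to compound 4 a step that the limit leaves unreadable from compound 3 to compound 4 is none beyond the scatter. For compound 4 the estimate is 80000 nM, range 20000 nM to 300000 nM, most likely reported again as a limit.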

Compound 4, half-maximal inhibitory concentration: > 50000 nM
Compound 4 was reported as a limit (the forecaster's own chance of this, stated with the estimate: 85%); the middle value does not contradict the limit.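

No step can be read between compound 3 and compound 4, since both are reported only as limits: the limit of > 50000 nM in this assay, at which 4 of the 4 values shown sit.

The compounds shown leave open which structural change, if any, would give a measurable value in this assay.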